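Swapping Fluorophenyl for Pyridyl on a Weakly Active Core

The compounds below may be only part of what the source reports. "The series", "measured", "known", "first", "only" and "open" are said of these compounds alone.

Compound 1, `N#Cc1ccc(Nc2nc(Oc3ccnc4ccccc34)nc(N3CCN(c4ccc(F)cc4)CC3)n2)cc1C(F)(F)F`, is one of three close relatives tested in a functional assay on DU-145 cells (Homo sapiens) for cytotoxicity, read by sulforhodamine B assay, with a stated time of 48 h; a higher number here means a weaker inhibitor of growth, a lower number a stronger inhibitor of growth. For compound 1 the result is only a limit of the assay, > 100000 nM. Compound 2, `N#Cc1ccc(Nc2nc(Oc3ccnc4ccccc34)nc(N3CCN(c4cccc(C(F)(F)F)c4)CC3)n2)cc1C(F)(F)F`, carries 3-(trifluoromethyl)phenyl in place of 4-fluorophenyl on an amine nitrogen in a ring, and in this assay compound 2 gives 74100 nM, so that an at least 1.3-fold lower number from compound 1 to compound 2 (0.13 log units; that floor lies within the scatter). Compound 3, `CCN1CCN(c2nc(Nc3ccc(C#N)c(C(F)(F)F)c3)nc(Oc3ccnc4ccccc34)n2)CC1`, carries ethyl at that same place. For compound 3 the result is again a limit of the assay, > 100000 nM. Hence a step that the two limits leave unreadable from compound 1 to compound 3, while an at least 1.3-fold higher number from compound 2 to compound 3 (0.13 log units; that floor lies within the scatter). Within the data shown here, in short, (the limit of > 100000 nM in this assay, at which 2 of the 3 values shown sit), and no measured step rises clearly above the scatter.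

Compound 4, `N#Cc1ccc(Nc2nc(Oc3ccnc4ccccc34)nc(N3CCN(c4ccccn4)CC3)n2)cc1C(F)(F)F`, differs from compound 1 as follows: pyridin-2-yl in place of 4-fluorophenyl on an amine nitrogen in a ring. The three measured steps all concern the same place, and none of them moves the number by more than the scatter, so the same is expected here. The step is therefore expected to be an at least 1.0-fold lower number from compound 1 to compound 4 (0.02 log units; that floor lies within the scatter), essentially nothing beyond the scatter. Compound 4 is estimated at 95000 nM in this assay, within a range from 40000 nM to 250000 nM, with a good chance that only a limit is reported again.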

Compound 4, concentration for total growth inhibition: > 100000 nM
Compound 4: only a limit was reported; the forecaster's own chance of this, stated with the estimate: 60%; middle value at least 1.0-fold (0.02 log units) away from the limit.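

In this assay, pyridin-2-yl is the first group shown at this place with a hetero atom in its aromatic ring and a hydrogen-bond acceptor, yet compound 4 again gives only a limit of the assay. The steps linking compound 4 with compound 1 and with compound 3 cannot be read, as limits stand on both sides. The one readable step is an at least 1.3-fold higher number from compound 2 to compound 4 (0.13 log units; that floor lies within the scatter), which adds to a flat picture at this place in which most values give no size at all: the limit of > 100000 nM in this assay, at which 3 of the 4 values shown sit.

The compounds shown leave open whether a quite different group at this place, such as a carboxylic acid or a longer chain ending in an amine, would give a reading clear of the limit. They also leave open whether a change elsewhere on the shared core, such as at the nitrile, would move the numbers.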